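Adding a double bond to the acid chain of compound 2

A few compounds are considered here, and "the series" means these few. Any claim that something is new, unique, unknown or untested is made for them only; others in the source may bear on it.

In an ADME assay on the whole organism (strain CD-1) for pharmacokinetics, with Mus musculus as the target, at a dose of 3 mg/kg by the intravenous route (on this read-out higher numbers stand for higher exposure at the dose given and lower numbers for lower exposure), compound 2 (`CC(CCOc1ccccc1CN(C)C(=O)c1ccc(-c2ccco2)cc1)CCC(=O)O`) gives 11800 ng.h/mL and compound 1 (`CC(CCCCOc1ccccc1CN(C)C(=O)c1ccc(-c2ccco2)cc1)C(=O)O`) gives 11400 ng.h/mL, level within the scatter. Compound 3 (`C/C(=C\COc1ccccc1CN(C)C(=O)c1ccc(-c2ccco2)cc1)CCC(=O)O`) carries 4-carboxy-2-methylbut-1-en-1-yl in place of 4-carboxy-2-methylbutyl on a saturated chain carbon bound to an oxygen on an aromatic ring. Within the data shown here, the only measured step, a 1.0-fold higher number from compound 1 to compound 2 (0.01 log units; within the scatter), also alters this chain and stays within the scatter, though it adds no double bond. No change beyond the scatter is therefore expected. The expected step is a 1.1-fold lower number from compound 2 to compound 3 (0.05 log units; within the scatter). The estimate for compound 3 is 10500 ng.h/mL, with a range of 5000 ng.h/mL to 21000 ng.h/mL.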

Compound 3, area under the concentration-time curve: 3300 ng.h/mL
The estimate for compound 3 lay 3.2-fold (0.50 log units) above the measured number; the measured number lies below the stated range.
By their numbers in this assay, from the lowest: compound 3; then compounds 1 and 2 (each within the scatter of the next).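

Unsaturating the chain on a saturated chain carbon bound to an oxygen on an aromatic ring changes exposure in this assay (a 3.6-fold lower number from compound 2 to compound 3 (0.55 log units; beyond the scatter)), whereas the saturated chains of compound 1 and compound 2 stay level within the scatter. Compound 3 also falls against compound 1 (a 3.5-fold lower number from compound 1 to compound 3 (0.54 log units; beyond the scatter)), so both saturated chains give the same reading of the 5-carboxy-3-methylpent-2-en-1-yl chain. Nothing measured explains this drop.

Still open, as far as these compounds go, is whether the opposite double-bond isomer, a triple bond or a cyclopropane ring would match compound 3 or compound 2. Also open, from the compounds shown here alone, is whether the drop persists with a longer chain.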